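A few compounds are considered here, and "the series" means these few. Any claim that something is new, unique, unknown or untested is made for them only; others in the source may bear on it.

Measured compounds:
compound 1 `O=C(Cn1cc(-c2ccc(F)cc2)nn1)Nc1nccs1` gives 190 nM
compound 2 `O=C(Cn1cc(-c2ccccc2Cl)nn1)Nc1nccs1` gives 60 nM
compound 3 `Cc1csc(NC(=O)Cn2cc(-c3ccncc3)nn2)n1` gives 100 nM

The three compounds were tested in a functional assay on BMDM cells (Mus musculus, strain C57BL/6) for inhibition, with a stated time of 2 days; on this read-out higher numbers stand for weaker inhibition and lower numbers for stronger inhibition. Compound 3 sits second highest among the three numbers, but its gap to compound 2 and its gap to compound 1 are both within the scatter of the measurement, so the three cannot be placed in any firm order.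

Among the measured compounds shown here, the only step measured so far between two compounds differing in a single place is a 3.2-fold lower number from compound 1 to compound 2 (0.50 log units; beyond the scatter), a change on the aryl ring attached to the triazole.

Compound 4 `O=C(Cn1cc(-c2ccncc2)nn1)Nc1nccs1` differs from compound 3 at the other end of the molecule: hydrogen in place of methyl on an aromatic carbon. For the measured compounds named here, no measured pair shows the effect of removing this methyl, and the step from compound 1 to compound 2 concerns a different part of the structure, so it offers no direct guidance. With nothing to point in either direction, compound 4 is expected to give a number close to compound 3, with a step of a 1.1-fold higher number from compound 3 to compound 4 (0.04 log units; within the scatter) that stays within the scatter.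

Compound 4 is therefore estimated at 110 nM in this assay, with a range from 45 nM to 270 nM.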

Compound 4, half-maximal inhibitory concentration: 2 nM
For compound 4 the middle estimate is 55-fold (1.74 log units) above the measured one; the whole stated range lies above it.
By their numbers in this assay, from the lowest: compound 4; then compounds 2, 3 and 1 (each within the scatter of the next, the first and the last beyond it).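

In this assay, the position on the aromatic carbon next to the ring nitrogen of the 1,3-thiazol-2-yl group proves highly sensitive: the change from 4-methyl-1,3-thiazol-2-yl to 1,3-thiazol-2-yl, a single methyl giving way to hydrogen, brings a 50-fold lower number from compound 3 to compound 4 (1.70 log units; beyond the scatter), a far larger step than the one seen earlier on the aryl group. With the unsubstituted 1,3-thiazol-2-yl group, the aryl position also spans a much wider range than before: pyridin-4-yl in place of 2-chlorophenyl gives a 30-fold lower number from compound 2 to compound 4 (1.48 log units; beyond the scatter), and pyridin-4-yl in place of 4-fluorophenyl gives a 95-fold lower number from compound 1 to compound 4 (1.98 log units; beyond the scatter). No measurement here accounts for the size of these steps.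

The compounds shown leave open whether a group other than methyl at this thiazole carbon, such as ethyl or chlorine, would give a similarly high number. They also leave open whether adding the methyl to the compounds bearing 2-chlorophenyl or 4-fluorophenyl would shift the number as strongly as it does with pyridin-4-yl.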